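A few compounds are considered here, and "the series" means these few. Any claim that something is new, unique, unknown or untested is made for them only; others in the source may bear on it.

Compound 1 `CC(C)CC(=O)N1CCc2cc(CNC(=O)C3CC3)ccc21` gives the lowest number of the three compounds examined in an assay on HEK293 cells for inhibition of Indoleamine 2,3-dioxygenase 1 (Homo sapiens), tested at 10 uM (a higher number here means more inhibition at the concentration tested (going by the name of the read-out), a lower number less inhibition), where compound 1 gives 35%. Compound 2 `CC(C)C(=O)N1CCc2cc(CNC(=O)c3cccs3)ccc21` gives 100% in this assay, and compound 3 `CCC(=O)N1CCc2cc(CNC(=O)c3cccc(F)c3)ccc21` gives 82%; both values lie beyond the scatter above that of compound 1. Compounds 2 and 3 each carry a different group on the carbonyl of the side-chain amide and also differ from compound 1 in the acyl group on the shared core, so no single change can be credited for their higher numbers. Compound 4 `CC(C)CC(=O)N1CCc2cc(CNC(=O)c3ccco3)ccc21` differs from compound 1 in one place: furan-2-yl in place of cyclopropyl on a carbonyl carbon. An increase in inhibition is expected from this change, by a step of a number 35 percentage points higher from compound 1 to compound 4 (beyond the scatter), though its size is uncertain. Compound 4 is therefore estimated at 70%, within a range of 40% to 95%.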

Compound 4, a percentage reported as inhibition, at one concentration (the size of the read-out at that concentration, not a potency): 100%
Compound 4: middle estimate off by 30 percentage points, on the low side; the measured number lies above the stated range.
By their numbers in this assay, from the lowest: compound 1; then compound 3; then compounds 2 and 4 (each within the scatter of the next).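

With the acyl group on the shared core unchanged, furan-2-yl in place of cyclopropyl on a carbonyl carbon gives a number 65 percentage points higher from compound 1 to compound 4 (beyond the scatter) in this assay. The group on this carbonyl carbon can therefore shift the number by a large amount on its own, without any change to that acyl group. Nothing available here explains the size of this step. Going by these compounds, it remains open whether a pyridin-2-yl ring or a plain phenyl ring at this place would give a similar number. On these data alone, it is also open whether the same step would appear with a different acyl group on the core.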